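The source may report more compounds than this note shows. Statements on the series, on what has been measured and on what is new or still open speak of the compounds shown alone.

Measured so far:
- compound 1 `O=C(O)c1cc(-c2cccc(COc3ccc4c(c3)CN(CC3CC3)C4=O)c2)ccc1Cl`: 85.7%
- compound 2 `O=C(O)c1cc(-c2cccc(COc3ccc4c(c3)CCN(C3CCCC3)C4=O)c2)ccc1Cl`: 66.9%

In an assay on HEK293 cells for positive allosteric modulation of metabotropic glutamate receptor 2 (Rattus norvegicus), read by thallium flux (a higher number here means a larger maximal response, a lower number a smaller maximal response), compound 1 gives 85.7% and stands highest of the two numbers available. Going by the values given here, its nearest neighbour, compound 2, gives 66.9% in this assay; the two values lie apart by more than the usual scatter, but compound 2 differs from compound 1 in more than one place, so no single step is counted between them and nothing is drawn from the gap beyond the two values themselves.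

Compound 3 `O=C(O)c1cc(-c2cccc(COc3ccc4c(c3)CN(C3CC3)C4=O)c2)ccc1Cl` is the next compound and has not yet been measured in this assay. It differs from compound 1 in one place: cyclopropyl in place of cyclopropylmethyl on an amide-type nitrogen in a ring. The cyclopropylmethyl leaves and the cyclopropyl enters on the amide-type nitrogen of the five-membered non-aromatic ring within the fused system; one carbon fewer sits between that nitrogen and the three-membered ring.

Among the compounds with values here, with no single-change step known, only a modest change is expected for this swap, and the expected step from compound 1 to compound 3 in this assay is a number 7.7 percentage points lower from compound 1 to compound 3 (within the scatter), a small lowering that may well stay within the usual scatter. Compound 3 is therefore estimated to give 78% in this assay, with a range from 62% to 92%.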

Compound 3, largest response reached (Emax), in percent of the reference or control that the assay uses: 64.9%
Beside the measured number, compound 3's estimate is 13.1 percentage points above it; the range from low to high includes it.
By their numbers in this assay, from the lowest: compounds 3 and 2 (each within the scatter of the next); then compound 1.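

Going by these compounds alone, the swap of cyclopropylmethyl for cyclopropyl on the amide-type nitrogen in a ring gives the first single-change step: in this assay the result is a number 20.8 percentage points lower from compound 1 to compound 3 (beyond the scatter). The earlier pair could not show this, since its two compounds differ in more than one place; here the three-membered ring stays and the core of compound 1 is unchanged, so the drop in maximal response goes with this one substituent change, from 4 heavy atoms to 3. Nothing at hand accounts for the size of this step, and it remains a single observation at this position.

Still open, on these data alone, is how this assay responds to a longer chain on the same nitrogen, such as cyclopropylethyl, to an open-chain isobutyl group, or to a chain ending in an amine. Also open, as far as these compounds go, is whether a change of this kind gives a step of similar size on the core of compound 2, which carries cyclopentyl at the corresponding nitrogen.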